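From Isopropyl Amide to Difluorophenyl Amide: Lipophilicity Outlook

A few compounds are considered here, and "the series" means these few. Any claim that something is new, unique, unknown or untested is made for them only; others in the source may bear on it.

Compound 3 `Cc1cc(C(=O)NC(C)C)nn1Cc1cc(Cl)ccc1OCc1ccccc1` stands at the top of the shown values in a physicochemical assay for lipophilicity, at pH 7.4; on this read-out lower numbers stand for lower lipophilicity and higher numbers for higher lipophilicity: compound 3 gives > 3.7, which is a limit of the assay and not a number. Compound 2 `CNC(=O)c1cc(C)n(Cc2cc(Cl)ccc2OCc2ccccc2)n1` also gives > 3.7, again a limit. Compound 1 `Cc1cc(C(=O)O)nn1Cc1cc(Br)ccc1OCc1ccccc1` gives 1.2 in this assay. The step that the two limits leave unreadable from compound 2 to compound 3 cannot be sized because the limit of > 3.7 in this assay, at which 2 of the 3 values shown sit, caps both ends of it. Compound 4 `Cc1cc(C(=O)Nc2c(F)cccc2F)nn1Cc1cc(Cl)ccc1OCc1ccccc1` differs from compound 3 by 2,6-difluorophenyl in place of isopropyl on an amide-type nitrogen. Within the data shown here, the one measured step at this amide-type nitrogen is unreadable, so no size for the change can be drawn from it; compound 3 is already at a limit. Compound 4 is therefore expected to remain at that limit, with an estimated step that the limit leaves unreadable from compound 3 to compound 4. Compound 4 is expected to give 4.8, between 4 and 5.6.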

Compound 4, distribution coefficient: 3.7
Estimate against measurement, compound 4: 1.10 log units above, and the stated range ends above it.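

In this assay, among these compounds, compound 4 gives 3.7, a measured number and not a limit, so 2,6-difluorophenyl on this amide-type nitrogen gives the first amide reading on the scale. Compound 2 and compound 3 each gave only a limit. The data show a number no higher from compound 3 to compound 4 (the limit leaves the size open), and likewise a number no higher from compound 2 to compound 4 (the limit leaves the size open). The size of these two steps cannot be read, because it is hidden by this limit: the limit of > 3.7 in this assay, at which 2 of the 4 values shown sit.

As far as these compounds go, how much of the isopropyl to 2,6-difluorophenyl change belongs to the ring and how much to its fluorine atoms stays open. A plain phenyl on the same nitrogen would bear on that question.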